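Turning One Double Bond from Z to E

This account rests on a few compounds, and the source may have more. Where it says the series, first, only, none or still open, it means among the compounds named here.

Among the measured compounds shown here, in a functional assay on K562 cells (Homo sapiens) for antiproliferative activity, read by resazurin assay, with a stated time of 72 h (a lower number here means a stronger inhibitor of growth, a higher number a weaker inhibitor of growth), compound 2 `CCCCCCCCCCCC/C=C\N(NC(=O)COC)C(=O)OC(C)(C)C` gives 28300 nM, the only true number so far. Compound 1 `CCCCCCCCCCCC/C=C\N(NC(=O)COC)C(=O)CCCCCCCCC` gives > 110000 nM, which is a limit of the assay and not a number. For the measured compounds named here, the one measured step, an at least 3.8-fold lower number from compound 1 to compound 2 (0.58 log units; beyond the scatter), puts tert-butoxy in place of nonyl on a carbonyl carbon and leaves the double bond as it was. Compound 3 `CCCCCCCCCCCC/C=C/N(NC(=O)COC)C(=O)OC(C)(C)C` differs from compound 2 in one way only: the two compounds have the same atoms and bonds and differ only in configuration as drawn: 1 of 1 stereo elements differ; a double bond is drawn Z in compound 2 and E in compound 3. Going by the values given here, no measured step changes a double bond, so the data offer no direction here, and no change beyond the scatter is expected in this assay. The best guide is therefore compound 2 at 28300 nM. The expected change is a 1.1-fold higher number from compound 2 to compound 3 (0.03 log units; within the scatter). For compound 3 the estimated value is 30000 nM, with an expected range from 11000 nM to 80000 nM.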

Compound 3, concentration for 50% growth inhibition: 41400 nM
For compound 3 the middle estimate is 1.4-fold (0.14 log units) below the measured one, and the stated range covers the measured number.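

Among the compounds shown here, compound 3 gives the first reading of this double bond, and in this assay turning it from Z to E gives a 1.5-fold higher number from compound 2 to compound 3 (0.17 log units; within the scatter). At this position, with tert-butoxy on the carbonyl carbon, the two drawn geometries cannot be told apart in this measurement, and both give true numbers rather than a limit. The comparison is a clean one, and the reading rests on a single fact: the fact that compounds 2 and 3 differ only in the configuration as drawn.

From the compounds shown here alone, whether the double bond matters as little with nonyl on the carbonyl carbon stays open, and compound 1 gives > 110000 nM, which is a limit and not a number. Also open, going by these compounds, is what an amine or a carboxylic acid placed elsewhere on the shared core would do in this assay.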